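Para-substituted anilines in the tosyl triazole series

The source may hold more compounds than are shown below. What is called first, only, known or untested is meant among the compounds shown, and "the series" means these compounds.

Values in a functional assay on NCI-H460 cells (Homo sapiens) for cytotoxicity, read by MTT assay, with a stated time of 72 h (a lower number here means a stronger inhibitor, a higher number a weaker inhibitor), are as follows
- compound 1 `Cc1ccc(S(=O)(=O)n2cc(COC3=C/C(=N\c4ccccc4)c4ccccc4C3=O)nn2)cc1` gives 7220 nM
- compound 2 `CC(=O)c1ccc(/N=C2\C=C(OCc3cn(S(=O)(=O)c4ccc(C)cc4)nn3)C(=O)c3ccccc32)cc1` gives 15800 nM
- compound 3 `Cc1ccc(/N=C2\C=C(OCc3cn(S(=O)(=O)c4ccc(C)cc4)nn3)C(=O)c3ccccc32)cc1` gives 8020 nM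
- compound 4 `COc1ccc(/N=C2\C=C(OCc3cn(S(=O)(=O)c4ccc(C)cc4)nn3)C(=O)c3ccccc32)cc1` is not yet measured

Compound 3 at 8020 nM lies within the scatter of both other compounds, and only compound 1 and compound 2 stand apart beyond it. The change to compound 4 is methoxy in place of methyl on an aromatic carbon with methoxy in place of methyl on an aromatic carbon, para to a large group. Bearing on it are a 1.1-fold higher number from compound 1 to compound 3 (0.05 log units; within the scatter) with methyl in place of hydrogen and a 2.2-fold higher number from compound 1 to compound 2 (0.34 log units; beyond the scatter) with acetyl in place of hydrogen, a modest step. The step of a 2.0-fold lower number from compound 2 to compound 3 (0.29 log units; within the scatter) with methyl in place of acetyl is also small. No step beyond the scatter is therefore expected in this assay for this change. The expected step is a 1.0-fold lower number from compound 3 to compound 4 (0.00 log units; within the scatter) in this measurement. For compound 4 the estimated value is 8000 nM with an expected range of 4000 nM to 16000 nM as its bounds.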

Compound 4, half-maximal inhibitory concentration: 8390 nM
The estimate for compound 4 lay 1.0-fold (0.02 log units) below the measured number; the measured number falls inside the stated range.
By their numbers in this assay, from the lowest: compounds 1, 3, 4 and 2 (each within the scatter of the next, the first and the last beyond it).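

In this assay, methoxy in place of methyl at this position, para to a large group, leaves the number within the scatter (a 1.0-fold higher number from compound 3 to compound 4 (0.02 log units; within the scatter)). Methoxy also stays within the scatter of hydrogen (a 1.2-fold higher number from compound 1 to compound 4 (0.07 log units; within the scatter)) and of acetyl (a 1.9-fold lower number from compound 2 to compound 4 (0.27 log units; within the scatter)), so compound 4 separates from no other compound, and only compound 1 and compound 2 stand apart. No measurement on hand explains this result.

Still open, as far as these compounds go, is whether an amine or a carboxylic acid at this position would move the number beyond the scatter.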